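From 2-fluorophenyl to 4-methoxyphenyl on the amine nitrogen

A few compounds are considered here, and "the series" means these few. Any claim that something is new, unique, unknown or untested is made for them only; others in the source may bear on it.

In a functional assay on MCF7 cells (Homo sapiens) for cytotoxicity, read by sulforhodamine B assay (a lower number here means a stronger inhibitor, a higher number a weaker inhibitor), compound 2 `C=C1[C@@H](OC(C)=O)C[C@@H]2[C@](C)(COC=O)[C@H](OC(C)=O)CC[C@@]2(C)[C@@H]1C[C@@H](Nc1ccccc1F)C1=CCOC1=O` gives 16400 nM. Compound 1 `C=C1[C@@H](OC(C)=O)C[C@@H]2[C@](C)(COC=O)[C@H](OC(C)=O)CC[C@@]2(C)[C@@H]1C[C@@H](Nc1ccccc1C(=O)O)C1=CCOC1=O` gives 30800 nM, within the scatter of compound 2, while compound 3 `C=C1[C@@H](OC(C)=O)C[C@@H]2[C@](C)(CO[Si](C)(C)C(C)(C)C)[C@H](OC(C)=O)CC[C@@]2(C)[C@@H]1C[C@@H](Nc1ccccc1F)C1=CCOC1=O` gives 2930 nM, clearly a lower number. Compound 4 `C=C1[C@@H](OC(C)=O)C[C@@H]2[C@](C)(COC=O)[C@H](OC(C)=O)CC[C@@]2(C)[C@@H]1C[C@@H](Nc1ccc(OC)cc1)C1=CCOC1=O` carries 4-methoxyphenyl in place of 2-fluorophenyl on an amine nitrogen. For the measured compounds named here, the closest precedent is the change on the same aromatic ring, a 1.9-fold lower number from compound 1 to compound 2 (0.27 log units; within the scatter). The larger 5.6-fold lower number from compound 2 to compound 3 (0.75 log units; beyond the scatter) lies elsewhere, on an oxygen on a saturated carbon, and bears little on this change. No step beyond the scatter is therefore expected in this assay, and the expected change is a 1.0-fold lower number from compound 2 to compound 4 (0.01 log units; within the scatter). Compound 4 is estimated at 16000 nM, with an expected range of 7000 nM to 36000 nM.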

Compound 4, half-maximal inhibitory concentration: 24200 nM
The estimate for compound 4 lay 1.5-fold (0.18 log units) below the measured number; the measured number falls inside the stated range.
By their numbers in this assay, from the lowest: compound 3; then compounds 2, 4 and 1 (each within the scatter of the next).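

In this assay, the aromatic group on the amine nitrogen now covers 2-carboxyphenyl, 2-fluorophenyl and 4-methoxyphenyl, and both new steps stay within the scatter (a 1.5-fold higher number from compound 2 to compound 4 (0.17 log units; within the scatter); a 1.3-fold lower number from compound 1 to compound 4 (0.10 log units; within the scatter)). Across these three compounds, this position has therefore shown no readable response to the aromatic group, including to the entry of 4-methoxyphenyl. Nothing available accounts for this flat result. Going by these compounds, it remains open whether a benzyl group or a longer alkyl chain on this nitrogen would shift the number. On these data alone, it is also open whether the silyl ether gain seen with compound 3 would carry over to the 4-methoxyphenyl series.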